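The source may report more compounds than this note shows. Statements on the series, on what has been measured and on what is new or still open speak of the compounds shown alone.

Working notes on the series. Three compounds share one core and differ only in the group attached to it. In a functional assay on HeLa cells (Homo sapiens) for antiproliferative activity, read by MTT assay, with a stated time of 48 h (a lower number here means a stronger inhibitor, a higher number a weaker inhibitor), compound 1 `O=c1c(-c2ccc(Cl)cc2)cn(C2CC2)c2cc(N3CCNCC3)c(F)cc12` gives 9300 nM. In this assay compound 2 `COc1ccc(-c2cn(C3CC3)c3cc(N4CCNCC4)c(F)cc3c2=O)cc1` gives 16500 nM. In this assay compound 3 `O=c1c(-c2cccc(Cl)c2)cn(C2CC2)c2cc(N3CCNCC3)c(F)cc12` gives 890 nM. The core difference 3-chlorophenyl in place of 4-chlorophenyl on an aromatic carbon carries a 10-fold lower number from compound 1 to compound 3 (1.02 log units; beyond the scatter), and a 19-fold lower number from compound 2 to compound 3 (1.27 log units; beyond the scatter). The change methoxy in place of chloro on an aromatic carbon carries a 1.8-fold higher number from compound 1 to compound 2 (0.25 log units; within the scatter). Compound 4 `COc1cccc(-c2cn(C3CC3)c3cc(N4CCNCC4)c(F)cc3c2=O)c1` is made from compound 3 by methoxy in place of chloro on an aromatic carbon, the same kind of change as from compound 1 to compound 2, though the place differs: para to a large group there, meta to a large group here. For compound 4 a step of a 1.7-fold higher number from compound 3 to compound 4 (0.23 log units; within the scatter) is expected, resting on the step of a 1.8-fold higher number from compound 1 to compound 2 (0.25 log units; within the scatter) seen for the same kind of change. Compound 4 is therefore estimated at 1500 nM, with a range from 500 nM to 5000 nM.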

Compound 4, half-maximal inhibitory concentration: 920 nM
Compound 4: the middle estimate sits 1.6-fold (0.21 log units) above what was measured; the measured number falls inside the stated range.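

In this assay, the new step, a 1.0-fold higher number from compound 3 to compound 4 (0.01 log units; within the scatter), agrees with the earlier step for methoxy in place of chloro: the same change on two cores in this assay, a 1.8-fold higher number (0.25 log units; within the scatter) from compound 1 to compound 2 and a 1.0-fold higher number (0.01 log units; within the scatter) from compound 3 to compound 4, 1.7-fold (0.23 log units) apart, within the scatter of two such steps The large differences instead go with the aryl group's substitution pattern, with an 18-fold lower number from compound 2 to compound 4 (1.25 log units; beyond the scatter) and a 10-fold lower number from compound 1 to compound 4 (1.00 log units; beyond the scatter), and all four compounds fit this pattern. For the compounds shown here, this rests on only two pairs with one shared core, so it shows that the change carries between the 4-substituted and 3-substituted phenyl settings in this assay, but not that it would carry to a different core or why the steps agree.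

From the compounds shown here alone, whether an amine or a carboxylic acid in place of chloro would give a similar step remains open. So does whether a longer chain in place of methoxy would keep the number of compound 4.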